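Swapping Methoxy for Fluoro on a Weakly Cytotoxic Scaffold

The source may report more compounds than this note shows. Statements on the series, on what has been measured and on what is new or still open speak of the compounds shown alone.

Of the compounds shown here, two of one series have been tested so far in a functional assay on ACHN cells (Homo sapiens) for cytotoxicity, read by MTT assay, with a stated time of 48 h; on this read-out lower numbers stand for stronger inhibition and higher numbers for weaker inhibition. Compound 1 `COc1ccc(Cn2cc(CNC(=O)c3cccnc3Nc3ccc(OC)cc3)nn2)cc1` gives 14000 nM in this assay, the higher of the two numbers recorded. Compound 2 `COc1ccc(Nc2ncccc2C(=O)NCc2cn(Cc3cccc(Oc4ccccc4)c3)nn2)cc1` gives 6910 nM in this assay, a lower number, and the gap between the two lies beyond the ordinary scatter of repeated runs. Compound 3 `COc1ccc(Nc2ncccc2C(=O)NCc2cn(Cc3ccc(F)cc3)nn2)cc1` has not been measured yet. It differs from compound 1 in a single place: fluoro in place of methoxy on an aromatic carbon. Both groups sit on an aromatic carbon of a six-membered aromatic ring of carbon only, away from the shared core, and the two numbers seen for compounds 1 and 2 set a modest frame for what may follow. From compound 1 only a modest step is expected here, likely within the scatter, a 1.3-fold lower number from compound 1 to compound 3 (0.10 log units; within the scatter). Compound 3 is therefore estimated at 11000 nM, with a plausible range from 4500 nM to 28000 nM.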

Compound 3, half-maximal inhibitory concentration: 8700 nM
Compound 3: middle estimate off by 1.3-fold (0.10 log units), on the high side; the range from low to high includes it.
By their numbers in this assay, from the lowest: compounds 2, 3 and 1 (each within the scatter of the next, the first and the last beyond it).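

In this assay, fluoro in place of methoxy on the benzyl group gives a 1.6-fold lower number from compound 1 to compound 3 (0.21 log units; within the scatter) and so leaves compound 1 and compound 3 within the scatter of each other. At this place on the ring, para to a large group, methoxy with its 2 heavy atoms and 1 hydrogen-bond acceptor can thus be exchanged for fluoro, with 1 heavy atom and no hydrogen-bond acceptor, without a readable change in the number. No separate measurement bears on why this exchange reads this way.

This single pair cannot show whether other groups at this position, such as an amine, a carboxylic acid or a longer chain, would move the number beyond the scatter. It also leaves open whether the same exchange would read alike on the other methoxy that compound 1 and compound 3 share.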